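Swapping the amide headgroup on a weak kinase-type scaffold

A few compounds are considered here, and "the series" means these few. Any claim that something is new, unique, unknown or untested is made for them only; others in the source may bear on it.

Compound 2 `COc1cc(N(C)C)c(NC(=O)c2ccncc2OC)cc1Nc1nccc(-c2cn(C)c3ccccc23)n1` and compound 1 `COc1cc(F)c(NC(=O)c2ccccn2)cc1Nc1nccc(-c2cn(C)c3ccccc23)n1` were both tested in a functional assay on NCI-H1975 cells (Homo sapiens) for antiproliferative activity, read by MTT assay, with a stated time of 72 h; a lower number here means a stronger inhibitor, a higher number a weaker inhibitor. Compound 2 gives 12100 nM, the lowest of the two numbers, while compound 1 gives 16500 nM, and the two values lie within the scatter of each other. Compound 3 `COc1cc(N(C)C)c(NC(=O)c2ccccn2)cc1Nc1nccc(-c2cn(C)c3ccccc23)n1` differs from compound 2 by one change: pyridin-2-yl in place of 3-methoxypyridin-4-yl on a carbonyl carbon. Going by the values given here, no measured pair shows the effect of this change on its own, so no step beyond the scatter is expected in this assay. Compound 3 is estimated at 14000 nM, with a range from 5000 nM to 40000 nM, a step of a 1.2-fold higher number from compound 2 to compound 3 (0.06 log units; within the scatter).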

Compound 3, half-maximal inhibitory concentration: 10400 nM
Beside the measured number, compound 3's estimate is 1.3-fold (0.13 log units) above it; the range from low to high includes it.
By their numbers in this assay, from the lowest: compounds 3, 2 and 1 (each within the scatter of the next).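

In this assay, pyridin-2-yl in place of 3-methoxypyridin-4-yl on a carbonyl carbon gives a 1.2-fold lower number from compound 2 to compound 3 (0.07 log units; within the scatter), so the methoxy-bearing headgroup is not needed to keep this level of activity. Dimethylamino in place of fluoro on an aromatic carbon gives a 1.6-fold lower number from compound 1 to compound 3 (0.20 log units; within the scatter), so neither change separates these compounds. No measured evidence bears on why these numbers stay so close. From the compounds shown here alone, whether a morpholine ring on the carbonyl carbon, or a longer amine chain in place of dimethylamino on the aromatic carbon, would give a step beyond the scatter remains open.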